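Replacing chloromethyl with a selenium-containing group

The compounds below may be only part of what the source reports. "The series", "measured", "known", "first", "only" and "open" are said of these compounds alone.

Measured in a functional assay on MGC-803 cells (Homo sapiens) for inhibition, read by MTT assay, with a stated time of 48 h; a higher number here means a weaker inhibitor, a lower number a stronger inhibitor:
compound 1 `COc1ccc(CN(C(=O)CCl)c2cc(OC)c(OC)c(OC)c2)cc1O`: 84 nM
compound 2 `COc1ccc(CN(C(=O)CN=[N+]=[N-])c2cc(OC)c(OC)c(OC)c2)cc1O`: 120 nM
compound 3 `COc1ccc(CN(C(=O)CCCl)c2cc(OC)c(OC)c(OC)c2)cc1O`: 140 nM

Compound 3 gives 140 nM, which lies within the scatter of both other compounds. Compound 4 `COc1ccc(CN(C(=O)C[Se]C#N)c2cc(OC)c(OC)c(OC)c2)cc1O` keeps the shared core and changes one group: a group of 3 heavy atoms (1 carbon, 1 nitrogen, 1 selenium; no ring) in place of a group of 2 heavy atoms (1 carbon, 1 chlorine; no ring), on a saturated chain carbon bound to a carbonyl carbon. Three measured steps at this same place bear on the change: a 1.7-fold higher number from compound 1 to compound 3 (0.22 log units; within the scatter), a 1.2-fold higher number from compound 2 to compound 3 (0.07 log units; within the scatter) and a 1.4-fold higher number from compound 1 to compound 2 (0.15 log units; within the scatter). All three stay within the scatter. As far as these compounds go, the entering group itself is untested, so the range is kept wide, but no step beyond the scatter is expected in this assay, in either direction. The expected change is a 1.3-fold lower number from compound 3 to compound 4 (0.10 log units; within the scatter). For compound 4 the estimate is 110 nM, with an expected range from 40 nM to 300 nM.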

Compound 4, half-maximal inhibitory concentration: 270 nM
Estimate against measurement, compound 4: 2.5-fold (0.39 log units) below; the range from low to high includes it.
By their numbers in this assay, from the lowest: compounds 1, 2, 3 and 4 (each within the scatter of the next, the first and the last beyond it).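

In this assay, going by these compounds alone, this selenium-containing group gives the first steps at this place that pass the scatter, both modest: a 3.2-fold higher number from compound 1 to compound 4 (0.51 log units; beyond the scatter) and a 2.3-fold higher number from compound 2 to compound 4 (0.35 log units; beyond the scatter) while a 1.9-fold higher number from compound 3 to compound 4 (0.29 log units; within the scatter) does not pass it. This place, a saturated chain carbon bound to a carbonyl carbon, therefore responds to some changes, though only modestly so far. No evidence here explains the shift.

As far as these compounds go, whether selenium or the nitrile carries the shift stays open, and a thiocyanate group would separate the two. From the compounds shown here alone, how an amine or a carboxylic acid would read at this place is also open.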